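Replacing a ring-bearing chain with a carboxy-bearing chain

The source may report more compounds than this note shows. Statements on the series, on what has been measured and on what is new or still open speak of the compounds shown alone.

Compound 1 `CCOc1ccc2c(=O)c(-c3ccc(O)cc3)coc2c1`: 40 nM
Compound 2 `O=c1c(-c2ccc(O)cc2)coc2cc(OCCC3OCCCO3)ccc12`: 400 nM

Going by the values given here, in an assay on isolated protein (Cricetulus griseus) for inhibition of aldehyde dehydrogenase, mitochondrial (Homo sapiens) (a lower number here means a stronger inhibitor, a higher number a weaker inhibitor), compound 2 gives the highest of the two numbers, with compound 1 showing a lower one, and the only measured step is a 10-fold higher number from compound 1 to compound 2 (1.00 log units; beyond the scatter). Compound 3 `O=C(O)CCCCCCOc1ccc2c(=O)c(-c3ccc(O)cc3)coc2c1` carries a group of 7 heavy atoms (5 carbon, 2 oxygen; no ring) in place of a group of 6 heavy atoms (4 carbon, 2 oxygen; one six-membered non-aromatic ring with 2 hetero atoms), on a saturated chain carbon, two bonds along the chain from an oxygen on an aromatic ring. That step from compound 1 to compound 2 bears on it only loosely, since compound 3 keeps a large group at the same place while dropping the ring, so no change beyond the scatter is expected. The estimated step is a 1.3-fold lower number from compound 2 to compound 3 (0.12 log units; within the scatter). Compound 3 is therefore expected at 300 nM, between 80 nM and 1200 nM.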

Compound 3, half-maximal inhibitory concentration: 9 nM
Estimate against measurement, compound 3: 33-fold (1.52 log units) above; the measured number lies below the stated range.
By their numbers in this assay, from the lowest: compound 3; then compound 1; then compound 2.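

In this assay, a large group at this place does not have to raise the number: 4-carboxybutyl in compound 3 gives a 44-fold lower number from compound 2 to compound 3 (1.65 log units; beyond the scatter) and also a 4.4-fold lower number from compound 1 to compound 3 (0.65 log units; beyond the scatter) against the shorter chain, so compound 3 is the strongest of the three. The ring-bearing group had pointed the other way, so the outcome depends on which group enters, not merely on a large group being present. Nothing at hand explains this difference.

Going by these compounds, it remains open whether the gain comes from the carboxylic acid or from the chain itself. A methyl ester, an unsubstituted alkyl chain, or a shorter or longer carboxy-bearing chain at this place would separate the two.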